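Compound 2 without its bromines: working notes

A few compounds are considered here, and "the series" means these few. Any claim that something is new, unique, unknown or untested is made for them only; others in the source may bear on it.

In a functional assay on PC-3 cells (Homo sapiens) for cytotoxicity, read by MTT assay, with a stated time of 72 h (on this read-out higher numbers stand for weaker inhibition and lower numbers for stronger inhibition), compound 1 (`O=C(N/N=C/c1ccc(F)cc1)Nc1cc2c(Nc3ccc(F)c(Cl)c3)ncnc2cc1O[C@H]1CCOC1`) is reported as "not active" (no number reported) with no number given. Within the data shown here, compound 2 (`O=C(N/N=C/c1cc(Br)c(O)c(Br)c1)Nc1cc2c(Nc3ccc(F)c(Cl)c3)ncnc2cc1O[C@H]1CCOC1`) gives 6160 nM as the only number so far, so it has no numeric neighbour to be ranked against. Compound 3 (`O=C(N/N=C/c1ccc(O)cc1)Nc1cc2c(Nc3ccc(F)c(Cl)c3)ncnc2cc1O[C@H]1CCOC1`) has yet to be read in this assay on the same terms. The change leading to it is 4-hydroxyphenyl in place of 3,5-dibromo-4-hydroxyphenyl on a carbon with a double bond to nitrogen and amounts to 4-hydroxyphenyl in place of 3,5-dibromo-4-hydroxyphenyl on a carbon with a double bond to nitrogen. Among the measured compounds shown here, no measured pair isolates this change. Compound 1 also carries no bromine and reads "not active" (no number reported) as the sole hint, which favours weaker inhibition for compound 3 without fixing a size. The expected move is a 2.4-fold higher number from compound 2 to compound 3 (0.39 log units; beyond the scatter) in the direction of weaker inhibition, modest but probably beyond the scatter. Compound 3 is estimated at 15000 nM with an expected range from 6000 nM to 50000 nM and a report without a number remains possible.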

Compound 3, half-maximal inhibitory concentration: 4890 nM
For compound 3 the middle estimate is 3.1-fold (0.49 log units) above the measured one; the whole stated range lies above it.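

Compound 2 without its bromines: the result

In this assay, replacing 3,5-dibromo-4-hydroxyphenyl with 4-hydroxyphenyl on the carbon with a double bond to nitrogen gives a 1.3-fold lower number from compound 2 to compound 3 (0.10 log units; within the scatter), so at this position the two bromines make no difference that can be told from the scatter of the assay. This also separates the missing bromines from the blank reading: compound 1 has no bromine and is reported as "not active" (no number reported), whereas compound 3 also has no bromine and gives 4890 nM, so lacking bromine does not by itself go with a report of no activity. No measurement at hand offers an explanation for either reading at this position.

The hydroxyl group is the obvious candidate for what separates compound 3 from compound 1, but with no number for compound 1 the size of that difference cannot be read, and two compounds with a number are too few to establish a role for the hydroxyl. From the compounds shown here alone, it also remains open how this position would read in this assay with a single bromine, a methoxy group in place of the hydroxyl, an amine or a carboxylic acid on the ring.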